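The compounds below may be only part of what the source reports. "The series", "measured", "known", "first", "only" and "open" are said of these compounds alone.

Measured compounds:

Compound 1 `O=C(c1cccc(C#Cc2ccccc2Nc2ncnc3ccc(Cl)nc23)c1)N1CCNCC1`
Compound 2 `CN(C)C(=O)c1cccc(C#Cc2ccccc2Nc2ncnc3ccc(Cl)nc23)c1`
Compound 3 `Cc1c(C(=O)N(C)C)oc2ccc(Nc3ncnc4ccc(Cl)nc34)cc12`

Compound 1 in an assay on isolated protein for inhibition of MAP kinase-interacting serine/threonine-protein kinase 1 (Homo sapiens), read by HTRF, in the presence of a further agent that is not named here (on this read-out higher numbers stand for weaker inhibition and lower numbers for stronger inhibition), gives only a limit, > 10000 nM. Compound 2 in this assay likewise gives only a limit, > 10000 nM. Compound 3 in this assay also gives only a limit, > 10000 nM. All three values sit at the same point, as noted in the limit of > 10000 nM in this assay, at which 3 of the 3 values shown sit, so no ordering among them can be read.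

Compound 1 differs from compound 2 by piperazin-1-yl in place of dimethylamino on a carbonyl carbon. The resulting step that the two limits leave unreadable from compound 2 to compound 1 cannot be sized, since both ends are limits. The two cores of compound 2 and compound 3 differ in more than one place, and that difference is not broken down here.

The unmeasured compound 4 `Cc1c(C(=O)N2CCNCC2)oc2ccc(Nc3ncnc4ccc(Cl)nc34)cc12` differs from compound 3 by piperazin-1-yl in place of dimethylamino on a carbonyl carbon. This is the same kind of change as that from compound 2 to compound 1, at a carbonyl carbon whose other neighbour is an aromatic carbon in both cases. The step from compound 3 to compound 4 in this assay is expected to be a step that the limit leaves unreadable from compound 3 to compound 4, i.e. no readable move, resting on the fact that the parallel step from compound 2 to compound 1 stayed within the limit, as noted in the limit of > 10000 nM in this assay, at which 3 of the 3 values shown sit, and that compound 3 itself returned only a limit, > 10000 nM. Compound 4 is therefore estimated at 15000 nM, with a plausible range from 5000 nM to 50000 nM, and most likely it will again be reported only as a limit.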

Compound 4, half-maximal inhibitory concentration: > 10000 nM
Compound 4: no number, only a limit (the forecaster's own chance of this, stated with the estimate: 85%); the middle value is on the limit's open side.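

The step between compound 3 and compound 4 cannot be read, as both return only a limit in this assay and the whole series rests at one point: the limit of > 10000 nM in this assay, at which 4 of the 4 values shown sit.

The compounds shown leave open whether any member of the series has a readable value in this assay and so how piperazin-1-yl and dimethylamino on a carbonyl carbon compare on either core.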